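The source may hold more compounds than are shown below. What is called first, only, known or untested is meant among the compounds shown, and "the series" means these compounds.

Of the compounds shown here, two have been tested in a functional assay on the whole organism (strain Wistar) for inhibition, with Rattus norvegicus as the target, read by paw edema, with stated times of 30 min and 3 h, at a dose of 200 mg/kg by the oral route; on this read-out higher numbers stand for more inhibition at the one dose given (going by the name of the read-out) and lower numbers for less inhibition. Compound 1 `O=C(O)c1cc(-n2c(-c3ccccc3)cc3c2CCCC3)cc(Cl)c1O` gives 0%. Compound 2 `COc1ccccc1-c1cc2c(n1-c1ccc(O)c(C(=O)O)c1)CCCC2` gives 50%, the higher of the two numbers, and its distance from compound 1 lies beyond the usual scatter of repeated measurements.

Compound 3 `O=C(O)c1cc(-n2c(-c3cccs3)cc3c2CCCC3)ccc1O` has not yet been measured. It differs from compound 2 in one place: thiophen-2-yl in place of 2-methoxyphenyl on an aromatic carbon. Among the compounds with values here, no pair of measured compounds shows what this exchange does, so its effect is open. Since compound 2 with its methoxyphenyl sits at 50% while compound 1 with a plain phenyl and an added chlorine sits at 0%, a smaller group in this position is expected to give a step from compound 2 to compound 3 of a number 20 percentage points lower from compound 2 to compound 3 (beyond the scatter), in the downward direction, though the uncertainty is wide. Compound 3 is therefore expected to give 30% in this assay, within a range from 0% to 60%.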

Compound 3, a percentage reported as inhibition, in the whole organism at one dose (the size of the read-out at that dose, not a potency): 30%
Estimate against measurement, compound 3: no gap at the digits printed; the measured number falls inside the stated range.
By their numbers in this assay, from the lowest: compound 1; then compound 3; then compound 2.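

Changing this one group moves the read-out: in this assay, replacing 2-methoxyphenyl with thiophen-2-yl on the aromatic carbon next to the ring nitrogen gives a step of a number 20 percentage points lower from compound 2 to compound 3 (beyond the scatter). Within the data shown here, the position is therefore sensitive to which aromatic ring it carries, something no earlier pair could show, and with the five-membered aromatic ring in place compound 3 still gives 30%. Nothing measured here explains the size or direction of this step.

This single exchange alters the ring size, the hetero atom and the methoxy group together, so the contribution of each cannot be separated. As far as these compounds go, how a pyridin-2-yl ring, a methyl group or an amine on this carbon would read out also remains open.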